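The source may hold more compounds than are shown below. What is called first, only, known or untested is meant among the compounds shown, and "the series" means these compounds.

Measured compounds:
- compound 1, `COc1cccc(OC)c1OCCNCCOc1ccccc1OCc1ccccc1[N+](=O)[O-]`: in a functional assay on PC-3 cells (Homo sapiens) for cytotoxicity, read by sulforhodamine B assay (on this read-out higher numbers stand for weaker inhibition of growth and lower numbers for stronger inhibition of growth), compound 1 gives 13200 nM
- compound 2, `COc1cccc(OC)c1OCCNCCOc1ccccc1OCc1cccc([N+](=O)[O-])c1`: in this assay compound 2 gives 13200 nM

Compound 2 stands level with compound 1 on the numbers shown; the one measured step, no change at the digits printed from compound 1 to compound 2 (within the scatter), moved the nitro group around its benzyl ring and left the read-out untouched within the scatter. Compound 3, `CCOc1ccc(COc2ccccc2OCCNCCOc2c(OC)cccc2OC)cc1`, differs from compound 2 by 4-ethoxyphenyl in place of 3-nitrophenyl on a saturated chain carbon bound to an oxygen on an aromatic ring. Going by the values given here, no measured step swaps the nitro group for an ethoxy group, so the only guidance is that the single earlier change at this same position, from compound 1 to compound 2, produced no change beyond the scatter. On that basis compound 3 is expected to stay close to compound 2, with an estimated step of a 1.0-fold lower number from compound 2 to compound 3 (0.01 log units; within the scatter) in this assay. Compound 3 is therefore estimated at 13000 nM, most likely between 5000 nM and 35000 nM.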

Compound 3, concentration for 50% growth inhibition: 5200 nM
The estimate for compound 3 lay 2.5-fold (0.40 log units) above the measured number; the range from low to high includes it.
By their numbers in this assay, from the lowest: compound 3; then compounds 1 and 2 (each within the scatter of the next).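

In this assay, the group on this saturated chain carbon can change the read-out: 4-ethoxyphenyl in place of 3-nitrophenyl gives a 2.5-fold lower number from compound 2 to compound 3 (0.40 log units; beyond the scatter) and 4-ethoxyphenyl in place of 2-nitrophenyl gives a 2.5-fold lower number from compound 1 to compound 3 (0.40 log units; beyond the scatter) in the same direction. Moving the nitro group around its ring had shown no such change, so this is the first sign that the position responds to what is placed there. No measured evidence on why these steps occur is available.

The compounds shown leave open whether the ethoxy group itself or its place on the ring carries the step, which a 3-ethoxyphenyl or a 4-nitrophenyl compound could separate. On these data alone, how a longer chain, such as 4-butoxyphenyl, or an amine, such as 4-aminophenyl, would read here also remains open.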